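Cytotoxicity notes: benzyl ether variation on the shared core

This account rests on a few compounds, and the source may have more. Where it says the series, first, only, none or still open, it means among the compounds named here.

Three compounds of the series have a reading in an ADME assay on MT4 cells (Homo sapiens) for cytotoxicity, read by MTT assay, with a stated time of 5 days; on this read-out lower numbers stand for higher toxicity in this test and higher numbers for lower toxicity in this test. Compound 1 `CN(C)c1ccnc(Nc2ccc(C#N)cc2)n1` gives 34000 nM. Compound 2 `N#Cc1ccc(Nc2nccc(OCc3ccccc3F)n2)cc1` gives 151000 nM. Compound 3 `N#Cc1ccc(Nc2nccc(OCc3ccc(F)cc3)n2)cc1` gives 81000 nM. On these three numbers compound 3 stands second highest; its nearest neighbour is compound 2, and the step of a 1.9-fold lower number from compound 2 to compound 3 (0.27 log units; within the scatter) lies within the scatter, while the gap to compound 1 lies beyond it.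

The next compound, compound 4 `N#Cc1ccc(Nc2nccc(OCc3cccc(C#N)c3)n2)cc1`, differs from compound 3 only at the saturated chain carbon bound to an oxygen on the aromatic ring: 3-cyanophenyl in place of 4-fluorophenyl on a saturated chain carbon bound to an oxygen on an aromatic ring.

For the measured compounds named here, the one measured step that bears on this change is the exchange at the same place from compound 2 to compound 3, a 1.9-fold lower number from compound 2 to compound 3 (0.27 log units; within the scatter), which did not move the read-out beyond the scatter. A substituted phenyl group remains on the chain carbon, and nothing in the measured set points to a shift in either direction. In this assay compound 4 is therefore expected near 80000 nM, with a range of 30000 nM to 200000 nM. The expected step of a 1.0-fold lower number from compound 3 to compound 4 (0.01 log units; within the scatter) is estimated to stay within the scatter.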

Compound 4, half-maximal cytotoxic concentration: 4100 nM
For compound 4 the middle estimate is 20-fold (1.29 log units) above the measured one; the measured number lies below the stated range.
By their numbers in this assay, from the lowest: compound 4; then compound 1; then compounds 3 and 2 (each within the scatter of the next).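

In this assay this position proved far from indifferent: 3-cyanophenyl in place of 4-fluorophenyl gives a 20-fold lower number from compound 3 to compound 4 (1.30 log units; beyond the scatter), and in place of 2-fluorophenyl it gives a 37-fold lower number from compound 2 to compound 4 (1.57 log units; beyond the scatter), whereas the exchange between the two fluorophenyl groups, a 1.9-fold lower number from compound 2 to compound 3 (0.27 log units; within the scatter), showed no such movement. Among the benzyl ethers shown, the read-out therefore separates compound 4 from compounds 2 and 3, which remain within the scatter of each other. No measurement at hand accounts for the size of this step.

Compound 4 differs from compounds 2 and 3 in both the substituent and its number on the phenyl group, so the nitrile and its placement cannot be told apart here. On these data alone, how an unsubstituted phenyl group, or a carboxylic acid or an amine in place of the nitrile, would read on the same chain carbon stays open.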